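Swapping the aryl group on the enone chain

The source may hold more compounds than are shown below. What is called first, only, known or untested is meant among the compounds shown, and "the series" means these compounds.

Measured compounds:
compound 1 `O=C(O)c1ccc(C(=O)/C(=C\c2ccc(Cl)c([N+](=O)[O-])c2)SCc2ccccc2F)cc1` gives 1000 nM
compound 2 `O=C(O)c1ccc(C(=O)/C(=C\c2ccc(Br)cc2)SCc2ccc(Br)cc2)cc1` gives 1000 nM

In a functional assay on DU-145 cells (Homo sapiens) for inhibition, read by trypan blue exclusion, with a stated time of 96 h (on this read-out lower numbers stand for stronger inhibition of growth and higher numbers for weaker inhibition of growth), compound 1 gives 1000 nM. In this assay compound 2 gives 1000 nM, level with compound 1 at the digits shown, within the scatter. The two differ at more than one place, so no single step can be read between them.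

Compound 3 `O=C(O)c1ccc(C(=O)/C(=C\c2ccc(Cl)c([N+](=O)[O-])c2)SCc2ccc(Br)cc2)cc1` has not been measured. From compound 2 it differs in one place: 4-chloro-3-nitrophenyl in place of 4-bromophenyl on a double-bonded chain carbon bound to a double-bonded chain carbon. The same 4-chloro-3-nitrophenyl is present in compound 1, whose value in this assay sits at the same level as compound 2, so the step from compound 2 to compound 3 is expected to stay within the scatter, no change at the digits printed from compound 2 to compound 3 (within the scatter), in no firm direction. Compound 3 is estimated at 1000 nM in this assay, within 400 nM to 2500 nM.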

Compound 3, concentration for 50% growth inhibition: 500 nM
The estimate for compound 3 lay 2.0-fold (0.30 log units) above the measured number; measured number inside the range.
By their numbers in this assay, from the lowest: compounds 3, 1 and 2 (each within the scatter of the next).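

In this assay, the change from 4-bromophenyl to 4-chloro-3-nitrophenyl on a double-bonded chain carbon bound to a double-bonded chain carbon can now be read on its own, as a 2.0-fold lower number from compound 2 to compound 3 (0.30 log units; within the scatter), so this position accepts both aryl groups without a shift beyond the scatter. The second place can also be read alone: 4-bromophenyl in place of 2-fluorophenyl on a saturated chain carbon bound to a sulfur gives a 2.0-fold lower number from compound 1 to compound 3 (0.30 log units; within the scatter), so that change also stays within the scatter. Nothing measured here bears on why these values fall where they do.

From the compounds shown here alone, whether a pyridine ring or an aminophenyl group at the first place would move the number beyond the scatter remains open. Going by these compounds, it is equally open what a longer chain at the sulfur would do, or an amide in place of the carboxylic acid.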